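The compounds below may be only part of what the source reports. "The series", "measured", "known", "first", "only" and "open" are said of these compounds alone.

Among the compounds with values here, compound 2 `COc1cc(-c2nn(-c3cccc(NC(=O)Nc4cccc(C(F)(F)F)c4)c3)cc2-c2ccncc2)ccc1Cl` is one of two compounds measured so far. In a functional assay on RXF 393 cells (Homo sapiens) for inhibition, read by sulforhodamine B assay, with a stated time of 48 h (on this read-out lower numbers stand for higher toxicity in this test and higher numbers for lower toxicity in this test), compound 2 gives 4830 nM, the lowest of the two numbers, yet compound 1 `COc1cc(-c2nn(-c3cccc(NC(=O)Nc4cc(C(F)(F)F)cc(C(F)(F)F)c4)c3)cc2-c2ccncc2)ccc1Cl` sits within the usual scatter of it. In this assay compound 1 gives 4900 nM. Within the data shown here, the only measured step, a 1.0-fold lower number from compound 1 to compound 2 (0.01 log units; within the scatter), swaps hydrogen for trifluoromethyl on an aromatic carbon and is flat. The unmeasured compound 3 `COc1cc(-c2nn(-c3cccc(NC(=O)c4ccccc4)c3)cc2-c2ccncc2)ccc1Cl` differs from compound 2 by phenyl in place of (3-(trifluoromethyl)phenyl)amino on a carbonyl carbon. Among the measured compounds shown here, this change is of a different kind from the measured step, which altered a substituent on that outer ring while the amino link to the carbonyl stayed in place; no measured step covers the loss of that link, and the expectation is accordingly broad. Compound 3 is estimated at 7000 nM, with a range of 2500 nM to 25000 nM, which means an expected step of a 1.4-fold higher number from compound 2 to compound 3 (0.16 log units; within the scatter) in this assay.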

Compound 3, concentration lethal to 50% of the cells: > 100000 nM
Compound 3: a limit, no number; the forecaster's own chance of this, stated with the estimate: 10%; at least 14-fold (1.15 log units) between middle value and limit.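

Putting phenyl in place of (3-(trifluoromethyl)phenyl)amino on the carbonyl carbon gives an at least 20-fold higher number from compound 2 to compound 3 (1.31 log units; beyond the scatter) in this assay, so toxicity in this test drops sharply. The earlier step, on a substituent of the outer ring, was flat, whereas this change at the carbonyl carbon has a large effect even though an aromatic ring of carbon stays in that part of the molecule. The figure for compound 3 is a limit of the assay and not a number: the limit of > 100000 nM in this assay, at which 1 of the 3 values shown sits.

This change removes the amino link and the trifluoromethyl group together, so the compounds shown cannot tell which loss matters. A plain phenylamino group without trifluoromethyl on the carbonyl carbon would separate the two, and a methylamino group would test the amino link without an aromatic ring.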